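A few compounds are considered here, and "the series" means these few. Any claim that something is new, unique, unknown or untested is made for them only; others in the source may bear on it.

In an ADME assay on MRC5 cells (Homo sapiens) for inhibition, with a stated time of 72 h (on this read-out higher numbers stand for an effect only at larger amounts of compound and lower numbers for an effect already at smaller amounts), three compounds have been measured:

Compound 1 `COc1cccc(OC)c1C(=O)Nc1c[nH]nc1C(=O)N[C@H]1CC[C@H](OC)CC1`: 31000 nM
Compound 2 `COc1cccc(OC)c1C(=O)Nc1c[nH]nc1C(=O)NCc1ccccn1`: > 50000 nM, a limit
Compound 3 `COc1cccc(OC)c1C(=O)Nc1c[nH]nc1C(=O)NCCCOC(C)C`: > 50000 nM, a limit

Compound 3 has no number and sits at the limit of > 50000 nM in this assay, at which 2 of the 3 values shown sit. Compound 4 `COc1cccc(OC)c1C(=O)Nc1c[nH]nc1C(=O)NC1CCCCCC1` carries cycloheptyl in place of 3-isopropoxypropyl on an amide-type nitrogen.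

The closest guide is an at least 1.6-fold higher number from compound 1 to compound 3 (0.20 log units; that floor lies within the scatter), where 4-methoxycyclohexyl gives way to the same chain. an at least 1.6-fold higher number from compound 1 to compound 2 (0.20 log units; that floor lies within the scatter) has the same floor, and both floors lie within the scatter. a step that the two limits leave unreadable from compound 2 to compound 3 adds nothing readable. Only a small step toward a lower number is therefore expected, estimated as an at least 1.4-fold lower number from compound 3 to compound 4 (0.15 log units; that floor lies within the scatter), and another limit remains possible. For compound 4 the estimated value is 35000 nM, with an expected range from 15000 nM to 60000 nM.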

Compound 4, half-maximal effective concentration: 42000 nM
The estimate for compound 4 lay 1.2-fold (0.08 log units) below the measured number; the range from low to high includes it.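

Cycloheptyl gives the second readable number at this amide-type nitrogen in this assay, which allows a direct comparison with 4-methoxycyclohexyl: a 1.4-fold higher number from compound 1 to compound 4 (0.13 log units; within the scatter). Against the two chains only floors can be read, an at least 1.1-fold lower number from compound 3 to compound 4 (0.07 log units; that floor lies within the scatter) and an at least 1.1-fold lower number from compound 2 to compound 4 (0.07 log units; that floor lies within the scatter). Compound 2 and compound 3 remain limits of the assay, not numbers: the limit of > 50000 nM in this assay, at which 2 of the 4 values shown sit.

Going by these compounds, what a smaller ring such as cyclobutyl, or a chain ending in an amine or a carboxylic acid, would give on this nitrogen stays open.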